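This account rests on a few compounds, and the source may have more. Where it says the series, first, only, none or still open, it means among the compounds named here.

Compound 1, `Nc1cc(N)c2nc(-c3ccccc3)c(Sc3ccc(F)cc3)nc2c1`, carries a (4-fluorophenyl)sulfanyl group on the shared core. Among the measured compounds shown here, in a functional assay on OVCAR-5 cells (Homo sapiens) for inhibition, read by sulforhodamine B assay, with a stated time of 48 h (a lower number here means a stronger inhibitor of growth, a higher number a weaker inhibitor of growth), compound 1 gives 19100 nM, the lower of the two numbers known so far. Its companion, compound 2, `COc1ccc(CNc2nc3cc(N)cc(N)c3nc2-c2ccccc2)cc1`, which bears a benzylamino group in the same position, gives 20900 nM in this assay; the two values lie within the scatter of each other, so neither can be called the more effective inhibitor of growth. The next compound to be measured, compound 3, `COc1ccc(Sc2nc3cc(N)cc(N)c3nc2-c2ccccc2)cc1`, differs from compound 1 in one place: methoxy in place of fluoro on an aromatic carbon. For the measured compounds named here, no measured pair here shows this exact change. Since compound 2 with 20900 nM and compound 1 with 19100 nM sit so close together despite a larger difference at this position, the step is expected to stay within the scatter, a 1.0-fold higher number from compound 1 to compound 3 (0.02 log units; within the scatter), and compound 3 is estimated at 20000 nM in this assay, within a range from 8000 nM to 50000 nM.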

Compound 3, concentration for 50% growth inhibition: < 100000 nM
Compound 3 ended at the assay's limit; the forecaster's own chance of this, stated with the estimate: 10%; the middle value does not contradict the limit.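

Among the compounds shown here, for compound 3 the result, < 100000 nM, is a limit of the assay and not a number, so no step between compound 1 and compound 3 can be read. The compounds shown leave open whether methoxy in place of fluoro at this position changes growth inhibition, and by how much.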